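This account rests on a few compounds, and the source may have more. Where it says the series, first, only, none or still open, it means among the compounds named here.

Compound 1 `COc1cc(C(=O)c2cn(-c3ccccc3)cc2-c2ccccc2Cl)cc(OC)c1OC`: 76 nM
Compound 2 `COc1cc(C(=O)c2cn(-c3ccccc3)cc2-c2cccc(Br)c2)cc(OC)c1OC`: 950 nM
Compound 3 `COc1cc(C(=O)c2cn(-c3ccccc3)cc2-c2ccccc2[N+](=O)[O-])cc(OC)c1OC`: 49 nM

All three values come from a functional assay on MCF7 cells (Homo sapiens) for cytotoxicity, read by MTT assay, with a stated time of 96 h; a higher number here means a weaker inhibitor, a lower number a stronger inhibitor. Compound 3 stands at the low end of these numbers, level within the scatter with its nearest neighbour: a 1.6-fold lower number from compound 1 to compound 3 (0.19 log units; within the scatter). Its furthest neighbour is well apart: a 19-fold lower number from compound 2 to compound 3 (1.29 log units; beyond the scatter).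

Compound 4 `COc1cc(C(=O)c2cn(-c3ccccc3)cc2-c2ccc([N+](=O)[O-])cc2)cc(OC)c1OC` has the same atoms as compound 3, joined differently: 4-nitrophenyl in place of 2-nitrophenyl on an aromatic carbon. Here 4-nitrophenyl stands in place of 2-nitrophenyl, on an aromatic carbon of a five-membered aromatic ring with 1 nitrogen.

Among the compounds with values here, no measured step moves a nitro group, and no measured compound carries a 4-nitrophenyl, so the guidance is indirect. The nearest guide is a 13-fold higher number from compound 1 to compound 2 (1.10 log units; beyond the scatter), a step that changes both the halogen and where it sits on the phenyl ring. The step of a 19-fold lower number from compound 2 to compound 3 (1.29 log units; beyond the scatter) points the same way when read in reverse. Among these three compounds, only compound 2 has a high number, and none goes against this reading. A large step towards a higher number is therefore expected, though the halogen change in that guide leaves its size uncertain.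

The estimated step in this assay is a 10-fold higher number from compound 3 to compound 4 (1.01 log units; beyond the scatter). For compound 4 the expected value is 500 nM, with an estimated range of 120 nM to 2000 nM.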

Compound 4, half-maximal inhibitory concentration: 590 nM
Estimate against measurement, compound 4: 1.2-fold (0.07 log units) below; the range from low to high includes it.
By their numbers in this assay, from the lowest: compounds 3 and 1 (each within the scatter of the next); then compounds 4 and 2 (each within the scatter of the next).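

Moving the nitro group while keeping every atom gives a large change in this assay (a 12-fold higher number from compound 3 to compound 4 (1.08 log units; beyond the scatter)), so where this group sits on the phenyl ring matters on its own, which no earlier step could show without also changing the group. The 4-nitrophenyl of compound 4 stays level with the 3-bromophenyl of compound 2 (a 1.6-fold lower number from compound 2 to compound 4 (0.21 log units; within the scatter)), but it lies clearly apart from the 2-chlorophenyl of compound 1 (a 7.8-fold higher number from compound 1 to compound 4 (0.89 log units; beyond the scatter)). Across these four compounds, the two phenyl rings with a group at the 2-position give the low numbers and the other two give the high numbers, and no compound shown goes against this split.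

No measurement here explains why the position of the group changes the cytotoxicity read-out. Going by these compounds, it also remains open whether an amine or a carboxylic acid in place of the nitro group on this phenyl ring would follow the same split.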